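The source may hold more compounds than are shown below. What is called first, only, known or untested is meant among the compounds shown, and "the series" means these compounds.

Compound 1 `CC1=CC[C@H](C(C)(C)NC(=S)N/N=C/c2ccc(O)cc2)CC1` gives 600 nM in a functional assay on PC-3 cells (Homo sapiens) for inhibition, read by sulforhodamine B assay, with a stated time of 48 h (on this read-out lower numbers stand for stronger inhibition of growth and higher numbers for weaker inhibition of growth), and stands second highest among the three numbers measured. Among the compounds with values here, its nearest neighbour is compound 2 `COc1cc(/C=N/NC(=S)NC(C)(C)[C@H]2CC=C(C)CC2)ccc1O`, which gives 300 nM in this assay; the step of a 2.0-fold lower number from compound 1 to compound 2 (0.30 log units; within the scatter) is the only single-point change recorded, and it stays within the scatter. Compound 3 `CC1=CC[C@H](C(C)(C)NC(=S)N/N=C/c2cccc([N+](=O)[O-])c2)CC1` gives 9500 nM in this assay, a far weaker result than compound 1. Compound 4 `CC1=CC[C@H](C(C)(C)NC(=S)N/N=C/c2cccs2)CC1` has not yet been measured; it differs from compound 1 by thiophen-2-yl in place of 4-hydroxyphenyl on a carbon with a double bond to nitrogen. Within the data shown here, no recorded step bears directly on this exchange: the step from compound 1 to compound 2 adds a group to the ring rather than replacing the ring, and the values of compound 3 and compound 1 show only that another aryl group can carry a much higher number. The thiophen-2-yl of compound 4 carries no hydrogen-bond donor where the 4-hydroxyphenyl of compound 1 carries one. Relative to compound 1, the number for compound 4 in this assay is expected to rise, a step of a 2.5-fold higher number from compound 1 to compound 4 (0.40 log units; beyond the scatter). The estimate for compound 4 is 1500 nM, in a range from 400 nM to 6000 nM.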

Compound 4, concentration for 50% growth inhibition: 17800 nM
Compound 4: the middle estimate sits 12-fold (1.07 log units) below what was measured; measured number above the stated range.
By their numbers in this assay, from the lowest: compounds 2 and 1 (each within the scatter of the next); then compounds 3 and 4 (each within the scatter of the next).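

In this assay, within the data shown here, the step of a 30-fold higher number from compound 1 to compound 4 (1.47 log units; beyond the scatter) is the first large single-point change on the carbon with a double bond to nitrogen, whereas the earlier step of a 2.0-fold lower number from compound 1 to compound 2 (0.30 log units; within the scatter) stayed within the scatter. It shows that replacing the whole aryl group here can move growth inhibition far more than adding methoxy to the ring, and the printed values place compound 4 within the scatter of compound 3, at the weak end of the four. The exchange changes the ring size, the hetero atom and the hydrogen-bond donor together, and nothing available explains the size of this step.

From the compounds shown here alone, it remains open which of those changes carries the loss. A plain phenyl, or an amine or a carboxylic acid in place of the hydroxyl of 4-hydroxyphenyl, would help to separate them.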